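A Methoxy Swap at the Cytotoxicity Limit

The source may report more compounds than this note shows. Statements on the series, on what has been measured and on what is new or still open speak of the compounds shown alone.

In an ADME assay on HPC cells (Homo sapiens) for cytotoxicity, with a stated time of 24 h (on this read-out higher numbers stand for lower toxicity in this test and lower numbers for higher toxicity in this test), compound 1 (`CN(C)c1ccc(/C=C2\CCC/C(=C\c3cccc([N+](=O)[O-])c3)C2=O)cc1`) gives > 400000 nM as a limit of the assay, not a number. Compound 2 (`O=C1/C(=C/c2ccc(F)cc2)CCC/C1=C\c1ccc([N+](=O)[O-])cc1`) likewise gives > 400000 nM as a limit. Compound 3 (`CN(C)c1ccc(/C=C2\CCC/C(=C\c3ccc([N+](=O)[O-])cc3)C2=O)cc1`) also stands at > 400000 nM as a limit, and no number is known for it. Going by the values given here, all the values so far sit at this same limit (the limit of > 400000 nM in this assay, at which 3 of the 3 values shown sit).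

Compound 4 (`COc1ccc(/C=C2\CCC/C(=C\c3ccc([N+](=O)[O-])cc3)C2=O)cc1`) has not yet been measured. Its change from compound 3 (methoxy in place of dimethylamino on an aromatic carbon) is methoxy in place of dimethylamino on an aromatic carbon, para to a large group. The closest measured step (a step that the two limits leave unreadable from compound 2 to compound 3) replaces a group on an aromatic carbon, and the other (a step that the two limits leave unreadable from compound 1 to compound 3) moves the nitro group's ring pattern elsewhere in the molecule. Neither has a readable size, and compound 3 offers only its limit (> 400000 nM) as a starting point. The step expected in this assay is therefore none beyond the scatter (a step that the limit leaves unreadable from compound 3 to compound 4) in either direction. Compound 4 is estimated at 500000 nM with an expected range from 250000 nM to 1000000 nM and would most likely be reported as a limit again.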

Compound 4, half-maximal cytotoxic concentration: > 400000 nM
Compound 4 ended at the assay's limit (the forecaster's own chance of this, stated with the estimate: 85%); the middle value is on the limit's open side.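

Compound 4, like compound 2 and compound 3, gives a limit of the assay and not a number, so neither step to compound 4 can be read: the limit of > 400000 nM in this assay, at which 4 of the 4 values shown sit.

The compounds shown leave open whether any of these changes alters the read-out in this assay at all.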